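Methyl and chloro variants on the shared core

A few compounds are considered here, and "the series" means these few. Any claim that something is new, unique, unknown or untested is made for them only; others in the source may bear on it.

Of the compounds shown here, three have been measured in an assay on isolated protein for inhibition of Amine oxidase [flavin-containing] B (Homo sapiens), read by fluorescence, with a stated time of 15 min; a higher number here means a weaker inhibitor, a lower number a stronger inhibitor. Compound 1 `COc1ccc(/C=C/c2cc(OC)cc(OC)c2/C=C/C(=O)c2cc3ccccc3oc2=O)cc1` gives 9170 nM. Compound 2 `COc1ccc(/C=C/c2cc(OC)cc(OC)c2/C=C/C(=O)c2cc3cc(C)ccc3oc2=O)cc1` gives 5090 nM. Compound 3 `COc1ccc(/C=C/c2cc(OC)cc(OC)c2/C=C/C(=O)c2cc3ccc(C)cc3oc2=O)cc1` gives 2780 nM. The steps among them are small: a 1.8-fold lower number from compound 1 to compound 2 (0.26 log units; within the scatter); a 3.3-fold lower number from compound 1 to compound 3 (0.52 log units; beyond the scatter); a 1.8-fold lower number from compound 2 to compound 3 (0.26 log units; within the scatter). On these numbers compound 3 gives the lowest value of the three, with compound 2 nearest and only compound 1 separated from it beyond the scatter.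

Compound 4 `COc1ccc(/C=C/c2cc(OC)cc(OC)c2/C=C/C(=O)c2cc3cc(Cl)ccc3oc2=O)cc1` has not yet been measured. It differs from compound 3 by a group of 12 heavy atoms (9 carbon, 2 oxygen, 1 chlorine; one six-membered aromatic ring of carbon only, one six-membered aromatic ring with 1 hetero atom) in place of a group of 12 heavy atoms (10 carbon, 2 oxygen; one six-membered aromatic ring of carbon only, one six-membered aromatic ring with 1 hetero atom), on a carbonyl carbon. Among the measured compounds shown here, no measured step replaces a methyl by a chlorine, so only the methyl steps bear on the question: the step from compound 1 to compound 3 was modest, and the other two steps stayed within the scatter. Compound 4 carries its single substituent on the same side of the shared core as compound 2 does. The expectation for compound 4 in this assay is therefore a number close to the values of compound 2 and compound 3, with a 1.4-fold higher number from compound 3 to compound 4 (0.16 log units; within the scatter), a step not expected to lie beyond the scatter. The estimate for compound 4 is 4000 nM, in the range 1500 nM to 10000 nM.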

Compound 4, half-maximal inhibitory concentration: > 60000 nM
Compound 4: no number, only a limit; the forecaster's own chance of this, stated with the estimate: 2%; middle value at least 15-fold (1.17 log units) from the limit.
By their numbers in this assay, from the lowest: compounds 3, 2 and 1 (each within the scatter of the next, the first and the last beyond it). At a limit, above all of these: compound 4.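

In this assay compound 4 is recorded only as a limit: the limit of > 60000 nM in this assay, at which 1 of the 4 values shown sits. Chloro in place of methyl on an aromatic carbon gives an at least 11-fold higher number from compound 2 to compound 4 (1.07 log units; beyond the scatter), and chloro in place of hydrogen gives an at least 6.5-fold higher number from compound 1 to compound 4 (0.81 log units; beyond the scatter), whereas methyl in place of hydrogen at the same position gives a 1.8-fold lower number from compound 1 to compound 2 (0.26 log units; within the scatter), so this position is not indifferent to the substituent it carries, and a change that leaves the heavy-atom count of the group unchanged can still move the number far. The comparison with compound 3, in which the whole group on the carbonyl carbon is exchanged, points the same way, with an at least 21-fold higher number from compound 3 to compound 4 (1.33 log units; beyond the scatter), and places compound 4 beyond the scatter from all three measured compounds.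

Going by these compounds, how far the true number of compound 4 lies past its limit stays open, so the full size of these steps is unknown. Also open, on these data alone, is whether the rise belongs to chloro alone or extends to fluoro, bromo, methoxy or an amine at this position, and whether chloro at the position that carries the methyl in compound 3 would behave the same.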